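Working notes on a chloro step

The source may hold more compounds than are shown below. What is called first, only, known or untested is meant among the compounds shown, and "the series" means these compounds.

Compound 1 (`Cc1ccc(-c2nc3ccccn3c2Sc2ccccc2)cc1`) reads > 100000 nM in a functional assay on SK-MEL-28 cells (Homo sapiens) for inhibition, read by MTT assay, with a stated time of 48 h (a higher number here means a weaker inhibitor, a lower number a stronger inhibitor), which is a limit and not a number. For the measured compounds named here, compound 2 (`c1ccc(Sc2c(-c3cccs3)nc3ccccn23)cc1`) gives 85300 nM in this assay, the only true number so far.

Compound 3 (`Clc1ccc(Sc2c(-c3cccs3)nc3ccccn23)cc1`) differs from compound 2 by chloro in place of hydrogen on an aromatic carbon: phenyl becomes 4-chlorophenyl. Going by the values given here, the one measured step, an at least 1.1-fold lower number from compound 1 to compound 2 (0.06 log units; that floor lies within the scatter), lies within the scatter at its floor and changes a different group, so it offers only weak guidance. Nothing measured yet tests a change on this phenyl ring. Compound 2 also sits close to the limit of > 100000 nM in this assay, at which 1 of the 2 values shown sits, so a weaker result may return only a limit. Among the compounds with values here, no step clearly beyond the scatter is expected, with a slight lean toward a lower number. The expected step is a 1.6-fold lower number from compound 2 to compound 3 (0.19 log units; within the scatter). For compound 3 the estimated value is 55000 nM, with an expected range of 18000 nM to 100000 nM.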

Compound 3, half-maximal inhibitory concentration: 77300 nM
The estimate for compound 3 lay 1.4-fold (0.15 log units) below the measured number; the range from low to high includes it.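

Chloro in place of hydrogen, on an aromatic carbon para to a large group, is the first change read on this phenyl ring, and in this assay it gives a 1.1-fold lower number from compound 2 to compound 3 (0.04 log units; within the scatter) and so no readable effect at this position. Compound 2 and compound 3 cannot be told apart in this assay, which means that this one chlorine leaves the read-out where the unsubstituted phenyl had it. Any change on this ring that gives a weaker result may return only a limit: the limit of > 100000 nM in this assay, at which 1 of the 3 values shown sits.

As far as these compounds go, whether an amine, a carboxylic acid or a methoxy group at this same place would give a step beyond the scatter remains open. Also open, from the compounds shown here alone, is whether chloro would read the same with 4-methylphenyl in place of thiophen-2-yl on the shared core.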